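A few compounds are considered here, and "the series" means these few. Any claim that something is new, unique, unknown or untested is made for them only; others in the source may bear on it.

Of the compounds shown here, three built on one shared core have been measured in an assay on isolated protein for inhibition of bone morphogenetic protein 1 (Homo sapiens); a lower number here means a stronger inhibitor, a higher number a weaker inhibitor. Compound 1 `COc1ccc(S(=O)(=O)N(Cc2cc(C)on2)[C@H](C)C(=O)NO)cc1` gives 230 nM, compound 2 `COc1ccc(S(=O)(=O)N(Cc2ccc(Cl)c(Cl)c2)[C@H](C)C(=O)NO)cc1` gives 120 nM, and compound 3 `COc1ccc(S(=O)(=O)N(Cc2ccc(SC)cc2)[C@H](C)C(=O)NO)cc1` gives 80 nM, the lowest of the three numbers. Of the steps leading to it, a 2.9-fold lower number from compound 1 to compound 3 (0.46 log units; beyond the scatter) is beyond the scatter, while a 1.5-fold lower number from compound 2 to compound 3 (0.18 log units; within the scatter) is not. Compound 4 `COc1ccc(S(=O)(=O)N(Cc2ccc(Br)cc2)[C@H](C)C(=O)NO)cc1` differs from compound 3 by bromo in place of methylsulfanyl on an aromatic carbon. Among the measured compounds shown here, no measured step swaps one substituent on this ring for another; the nearest guide is the step that replaces 3,4-dichlorophenyl, a 1.5-fold lower number from compound 2 to compound 3 (0.18 log units; within the scatter), which lies within the scatter. The step expected is therefore a 1.4-fold higher number from compound 3 to compound 4 (0.14 log units; within the scatter), none beyond the scatter. The estimate for compound 4 is 110 nM, with a range from 50 nM to 250 nM.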

Compound 4, half-maximal inhibitory concentration: 37 nM
Compound 4: the middle estimate sits 3.0-fold (0.47 log units) above what was measured; the whole stated range lies above it.
By their numbers in this assay, from the lowest: compound 4; then compounds 3, 2 and 1 (each within the scatter of the next, the first and the last beyond it).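

Swapping one substituent for another on this ring does move the number: with bromo in place of methylsulfanyl, the result is a 2.2-fold lower number from compound 3 to compound 4 (0.33 log units; beyond the scatter), a step beyond the scatter. The other two steps, a 3.2-fold lower number from compound 2 to compound 4 (0.51 log units; beyond the scatter) and a 6.2-fold lower number from compound 1 to compound 4 (0.79 log units; beyond the scatter), also lie beyond it, making this 4-bromophenyl compound the strongest inhibitor of the four. Nothing available explains the size of this change.

On these data alone, it remains open whether iodo, an amine or a carboxylic acid on the same aromatic carbon would give a lower or a higher number.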